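Swapping a 2-methylphenyl for a 4-chlorophenyl amide

The compounds below may be only part of what the source reports. "The series", "measured", "known", "first", "only" and "open" are said of these compounds alone.

Measured compounds:
compound 1, `O=C(Nc1cc(-c2ccccc2)nn1-c1ccccc1)c1ccccc1`, 40 nM
compound 2, `Cc1ccccc1C(=O)Nc1cc(-c2ccccc2)nn1-c1ccccc1`, > 10000 nM

In an assay on CHO cells with metabotropic glutamate receptor 5 (Homo sapiens) as the target (on this read-out higher numbers stand for an effect only at larger amounts of compound and lower numbers for an effect already at smaller amounts), compound 1 gives 40 nM. For compound 2 only the limit of > 10000 nM in this assay, at which 1 of the 2 values shown sits, is known, so it stands at the weak end of the range shown. The step of an at least 250-fold higher number from compound 1 to compound 2 (2.39 log units; beyond the scatter) was the only one measured. Compound 3, `O=C(Nc1cc(-c2ccccc2)nn1-c1ccccc1)c1ccc(Cl)cc1`, differs from compound 2 by 4-chlorophenyl in place of 2-methylphenyl on a carbonyl carbon. This removes the methyl whose introduction produced the large step from compound 1, so compound 3 is expected to move back toward compound 1 by a large step downward, an at least 160-fold lower number from compound 2 to compound 3 (2.22 log units; beyond the scatter). Compound 3 is therefore estimated at 60 nM, in the range 15 nM to 300 nM.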

Compound 3, half-maximal effective concentration: 20 nM
Estimate against measurement, compound 3: 3.0-fold (0.48 log units) above; measured number inside the range.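

In this assay the change to 4-chlorophenyl gives an at least 500-fold lower number from compound 2 to compound 3 (2.69 log units; beyond the scatter) and shows that this aryl group on the carbonyl carbon can carry a substituent without the loss seen with compound 2. The chloro group on its own gives a 2.0-fold lower number from compound 1 to compound 3 (0.30 log units; within the scatter) and so leaves compound 3 level with compound 1. Compound 2 is known only as a limit, so the first step has a minimum size and no exact one: the limit of > 10000 nM in this assay, at which 1 of the 3 values shown sits.

On these data alone, whether the loss with compound 2 belongs to the methyl itself or to where it sits stays open. So does how a methoxy group or a nitrile would fare on this ring.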